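A few compounds are considered here, and "the series" means these few. Any claim that something is new, unique, unknown or untested is made for them only; others in the source may bear on it.

Within the data shown here, compound 1 `COc1ccc(C(=O)Oc2cc3c(cc2C)[C@@H](C(C)C)CC=C3C)cc1` gives 18.6% in a functional assay on SK-LU-1 cells (Homo sapiens) for antiproliferative activity, read by sulforhodamine B assay, with a stated time of 48 h, tested at 50 uM (on this read-out higher numbers stand for more inhibition at the one concentration tested (going by the name of the read-out) and lower numbers for less inhibition), the lowest of the two numbers measured so far, while compound 2 `CC1=CC[C@H](C(C)C)c2cc(C)c(OC(=O)c3cccc([N+](=O)[O-])c3)cc21` gives 60.4%. Among the measured compounds shown here, the one measured step, a number 41.8 percentage points higher from compound 1 to compound 2 (beyond the scatter), shows that swapping the group on the carbonyl carbon can shift this assay strongly. Compound 3 `CC1=CC[C@H](C(C)C)c2cc(C)c(OC(=O)c3ccccc3)cc21` differs from compound 1 by hydrogen in place of methoxy on an aromatic carbon. For the measured compounds named here, no measured step covers this change directly, so the guidance is indirect. A modest rise is expected, a number 11.4 percentage points higher from compound 1 to compound 3 (beyond the scatter). Compound 3 is therefore estimated at 30%, with a range from 10% to 55%.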

Compound 3, a percentage reported as inhibition, at one concentration (the size of the read-out at that concentration, not a potency): 37%
Compound 3: middle estimate off by 7 percentage points, on the low side; the measured number falls inside the stated range.
By their numbers in this assay, from the lowest: compound 1; then compound 3; then compound 2.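

With the bare phenyl ring of compound 3 as a reference point, the two substituents turn out to act in opposite directions in this assay. Hydrogen in place of methoxy raises the number (a number 18.4 percentage points higher from compound 1 to compound 3 (beyond the scatter)), while hydrogen in place of nitro lowers it (a number 23.4 percentage points lower from compound 2 to compound 3 (beyond the scatter)), so methoxy goes with less inhibition and nitro with more. No measurement here explains either shift. Since 4-methoxyphenyl and 3-nitrophenyl differ in both group and ring position, the effects of the two remain tangled. From the compounds shown here alone, how 4-nitrophenyl, 3-methoxyphenyl or an amine on this ring would compare stays open.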